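This account rests on a few compounds, and the source may have more. Where it says the series, first, only, none or still open, it means among the compounds named here.

Compound 1 `CCC[C@H](NC(=O)[C@@H]1C[C@@H]2CN1C(=O)[C@H](C(C)(C)C)NC(=O)OCCCCCCc1cccc3c1CN(C3)C(=O)O2)C(=O)C(=O)CC1CC1` and compound 2 `C=CCNC(=O)C(=O)[C@H](CCC)NC(=O)[C@@H]1C[C@@H]2CN1C(=O)[C@H](C(C)(C)C)NC(=O)OCCCCCCc1cccc3c1CN(C3)C(=O)O2` share the same core and differ only in that compound 2 carries an allylamino group in place of the cyclopropylmethyl on a carbonyl carbon. In an ADME assay on Huh-7 cells (Homo sapiens) for cytotoxicity (on this read-out higher numbers stand for lower toxicity in this test and lower numbers for higher toxicity in this test), compound 1 gives > 50000 nM, which is a limit of the test rather than a number. In this assay compound 2 gives > 50000 nM, again a limit. For the measured compounds named here, the step that the two limits leave unreadable from compound 1 to compound 2 therefore cannot be read, and the limit of > 50000 nM in this assay, at which 2 of the 2 values shown sit, shows that compound 2 stands at that limit together with the only other value. Compound 3 `CCC[C@H](NC(=O)[C@@H]1C[C@@H]2CN1C(=O)[C@H](C(C)(C)C)NC(=O)OCCCCCCc1cccc3c1CN(C3)C(=O)O2)C(=O)C(=O)NCc1ccccn1` differs from compound 2 in one place: pyridin-2-yl in place of vinyl on a saturated chain carbon bound to an amide-type nitrogen. Because of the limit of > 50000 nM in this assay, at which 2 of the 2 values shown sit, nothing measured here points to any change in this assay, so the step that the limit leaves unreadable from compound 2 to compound 3 is expected to be none beyond the scatter. Compound 3 is therefore estimated at 60000 nM, with a range from 25000 nM to 150000 nM, and most likely again reported only as a limit.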

Compound 3, half-maximal cytotoxic concentration: > 50000 nM
Compound 3: no number, only a limit (the forecaster's own chance of this, stated with the estimate: 75%); the middle value lies beyond the limit too.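

For the compounds shown here, compound 3, like compound 1 and compound 2, gives only a limit of the test and not a number, so no step among the three can be read in this assay: the limit of > 50000 nM in this assay, at which 3 of the 3 values shown sit.
The compounds shown leave open whether these groups on the shared core differ at all in this assay, and how far past the limit each compound lies.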